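Piperidin-1-yl in place of phenyl in compound 1

The source may hold more compounds than are shown below. What is called first, only, known or untested is meant among the compounds shown, and "the series" means these compounds.

Within the data shown here, in an ADME assay on CCRF-CEM cells (Homo sapiens) for cytotoxicity, read by cell counting (a higher number here means that more compound is tolerated, a lower number that less compound is tolerated), compound 1 (`Cc1cc(C)cc(S(=O)(=O)c2c(C(=O)NCc3ccccc3)[nH]c3ccc(Br)cc23)c1`) gives 172000 nM and stands highest of the two numbers so far, while compound 2 (`Cc1cc(C)cc(S(=O)(=O)c2c(C(=O)NCc3ccccc3)[nH]c3ccc([N+](=O)[O-])cc23)c1`) gives 8000 nM as the lower one. Compound 3 (`Cc1cc(C)cc(S(=O)(=O)c2c(C(=O)NCN3CCCCC3)[nH]c3ccc(Br)cc23)c1`) has not yet been measured. It carries piperidin-1-yl in place of phenyl on a saturated chain carbon bound to an amide-type nitrogen. Among the measured compounds shown here, the only measured step, a 22-fold lower number from compound 1 to compound 2 (1.33 log units; beyond the scatter) for nitro in place of bromo on an aromatic carbon, lies elsewhere in the structure and does not test this change. It shows only that a single replacement can move the number far in this pair. With compound 1 at the top of the two numbers, a moderate fall is expected, smaller than that step. The expected move is a 2.9-fold lower number from compound 1 to compound 3 (0.46 log units; beyond the scatter) and remains a rough expectation. Compound 3 is estimated at 60000 nM (range 15000 nM to 200000 nM).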

Compound 3, half-maximal cytotoxic concentration: 10000 nM
For compound 3 the middle estimate is 6.0-fold (0.78 log units) above the measured one; the measured number lies below the stated range.
By their numbers in this assay, from the lowest: compounds 2 and 3 (each within the scatter of the next); then compound 1.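

In this assay, piperidin-1-yl in place of phenyl on a saturated chain carbon bound to an amide-type nitrogen gives a 17-fold lower number from compound 1 to compound 3 (1.24 log units; beyond the scatter) while the bromo stays in place. Until now, the only place shown to move this number was the aromatic carbon that carries bromo, with a 22-fold lower number from compound 1 to compound 2 (1.33 log units; beyond the scatter), so the benzylcarbamoyl side of compound 1 is now a second place where a single replacement has a large effect. Nothing available explains what in this exchange of rings lies behind the step.

The compounds shown leave open whether cyclohexyl in place of phenyl would give a similar step, and whether morpholin-4-yl would behave like piperidin-1-yl. They also leave open how nitro and piperidin-1-yl would act together in one compound.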